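Aryl swaps on the shared core, up to compound 4

The source may report more compounds than this note shows. Statements on the series, on what has been measured and on what is new or still open speak of the compounds shown alone.

Compound 1 `CCOc1ccc(-c2ccc3ncn(-c4cc(OC)c(OC)c(OC)c4)c3c2)cc1`: 1710 nM
Compound 2 `COc1cc(-n2cnc3ccc(-c4ccc([N+](=O)[O-])cc4)cc32)cc(OC)c1OC`: 740 nM
Compound 3 `COc1cc(-n2cnc3ccc(-c4cccc(O)c4)cc32)cc(OC)c1OC`: 350 nM

All three values come from a functional assay on MCF7 cells (Homo sapiens) for antiproliferative activity, read by MTT assay, with a stated time of 72 h; a lower number here means a stronger inhibitor, a higher number a weaker inhibitor. Compound 3 has the lowest number of the three, and its gaps to both others lie beyond the scatter. Compound 4 `COc1cc(-n2cnc3ccc(-c4cccc(C)c4C)cc32)cc(OC)c1OC` carries 2,3-dimethylphenyl in place of 3-hydroxyphenyl on an aromatic carbon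

Going by the values given here, two measured steps bear most directly on this change, as both arrive at the 3-hydroxyphenyl group from another aryl group: a 2.1-fold lower number from compound 2 to compound 3 (0.33 log units; beyond the scatter) and a 4.9-fold lower number from compound 1 to compound 3 (0.69 log units; beyond the scatter). Both are modest. Leaving the 3-hydroxyphenyl group has so far meant a higher number, but this rests on only these two comparisons, and no measured compound carries 2,3-dimethylphenyl. A modest step towards a higher number is therefore expected in this assay. The expected step is a 2.3-fold higher number from compound 3 to compound 4 (0.36 log units; beyond the scatter). For compound 4 the estimated value is 800 nM, with an expected range from 280 nM to 2200 nM.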

Compound 4, half-maximal inhibitory concentration: 2150 nM
Estimate against measurement, compound 4: 2.7-fold (0.43 log units) below; the range from low to high includes it.
By their numbers in this assay, from the lowest: compound 3; then compound 2; then compounds 1 and 4 (each within the scatter of the next).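

In this assay, exchanging the 3-hydroxyphenyl group for 2,3-dimethylphenyl on this aromatic carbon gives a 6.1-fold higher number from compound 3 to compound 4 (0.79 log units; beyond the scatter), and the new group also compares unfavourably with 4-nitrophenyl, with a 2.9-fold higher number from compound 2 to compound 4 (0.46 log units; beyond the scatter). Against 4-ethoxyphenyl it shows no separation, with a 1.3-fold higher number from compound 1 to compound 4 (0.10 log units; within the scatter), so all three other aryl groups now give higher numbers than compound 3, and no compound shown goes against this. No supporting data are available to account for these differences.

Still open, as far as these compounds go, is whether the lower number of compound 3 follows from the hydroxyl itself or from where it sits on the ring. A 3-methoxyphenyl, 3-aminophenyl or 4-hydroxyphenyl group would bear on that, and a single methyl in place of the two in compound 4 would test the dimethyl pattern.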